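Compound 3 to Compound 4: Replacing the Pyridin-3-yl Group

The source may report more compounds than this note shows. Statements on the series, on what has been measured and on what is new or still open speak of the compounds shown alone.

In an ADME assay on AGS cells (Homo sapiens) for cytotoxicity, read by neutral red uptake, with a stated time of 24 h (a higher number here means a weaker inhibitor, a lower number a stronger inhibitor), compound 1 `CC(C)C(=O)Oc1c(C(C)C)cc2c3c1OC(=O)[C@@]31CCCC(C)(C)[C@@H]1CC2` gives 105000 nM, compound 2 `CCCCCCCCCCCC(=O)Oc1c(C(C)C)cc2c3c1OC(=O)[C@@]31CCCC(C)(C)[C@@H]1CC2` gives 413000 nM and compound 3 `CC(C)c1cc2c3c(c1OC(=O)c1cccnc1)OC(=O)[C@@]31CCCC(C)(C)[C@@H]1CC2` gives 280000 nM. The standing of compound 3 is only partly settled: there is a 2.7-fold higher number from compound 1 to compound 3 (0.43 log units; beyond the scatter), yet also a 1.5-fold lower number from compound 2 to compound 3 (0.17 log units; within the scatter), so it is clear of the lowest number and level with the other.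

Compound 4 `CC(C)c1cc2c3c(c1OC(=O)Cc1c[nH]c4ccccc14)OC(=O)[C@@]31CCCC(C)(C)[C@@H]1CC2` changes the same site, with (1H-indol-3-yl)methyl in place of pyridin-3-yl on a carbonyl carbon. Among the compounds with values here, no measured step makes this exact exchange, and no measured compound carries an indole. The closest evidence comes from the three exchanges at this site, which are modest or smaller: a 3.9-fold higher number from compound 1 to compound 2 (0.59 log units; beyond the scatter), a 2.7-fold higher number from compound 1 to compound 3 (0.43 log units; beyond the scatter) and the step from the undecyl to the pyridin-3-yl group already given. Any expectation therefore stays close to the existing numbers, and the estimated move in this assay is a 1.2-fold lower number from compound 3 to compound 4 (0.09 log units; within the scatter), which is expected to stay within the scatter. Compound 4 is expected at about 230000 nM, with an estimated range of 100000 nM to 500000 nM.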

Compound 4, half-maximal inhibitory concentration: 85600 nM
Compound 4: middle estimate off by 2.7-fold (0.43 log units), on the high side, and the stated range ends above it.
By their numbers in this assay, from the lowest: compounds 4 and 1 (each within the scatter of the next); then compounds 3 and 2 (each within the scatter of the next).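

Within the data shown here, with a 3.3-fold lower number from compound 3 to compound 4 (0.51 log units; beyond the scatter) and a 4.8-fold lower number from compound 2 to compound 4 (0.68 log units; beyond the scatter), this assay gives the first changes on this carbonyl carbon that lower the number beyond the scatter. The isopropyl group of compound 1 no longer stands alone at the low end of the series, since the (1H-indol-3-yl)methyl group is level with it, at a 1.2-fold lower number from compound 1 to compound 4 (0.09 log units; within the scatter), and the low end is therefore not tied to the isopropyl group. Why the (1H-indol-3-yl)methyl and pyridin-3-yl groups part in this way is something no available measurement explains.

Still open, on these data alone, is whether the indole itself or its methyl link carries the change, a question that a benzyl group on the same carbonyl carbon would help to separate. Also open, as far as these compounds go, is how a chain ending in an amine or a carboxylic acid would read at this site.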